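An Ethyl-for-Tolyl Swap Carried Across Two Cores

A few compounds are considered here, and "the series" means these few. Any claim that something is new, unique, unknown or untested is made for them only; others in the source may bear on it.

Compound 1 `CCNc1nnc(-c2cc(-c3ccc(F)cc3F)ccc2O)s1`, compound 2 `Cc1ccc(Nc2nnc(-c3cc(-c4ccc(F)cc4F)ccc3O)s2)cc1` and compound 3 `Cc1ccc(Nc2nnc(-c3cc(-c4ccc(F)cc4F)ccc3O)o2)cc1` were tested in a functional assay on the whole organism (strain BALB/c) for inhibition, with Mus musculus as the target, read by paw edema, with a stated time of 4 h, at a dose of 50 mg/kg by the oral route; a lower number here means less inhibition, a higher number more inhibition at the dose given (going by the name of the read-out). In this assay compound 1 gives 50.2%, compound 2 gives 43.5% and compound 3 gives 33.8%. Compound 2 and compound 1 differ in one place, (ethyl in place of 4-methylphenyl on a nitrogen on an aromatic ring), and that change made a number 6.7 percentage points higher from compound 2 to compound 1 (within the scatter). The same change, (ethyl in place of 4-methylphenyl on a nitrogen on an aromatic ring), turns compound 3 into compound 4 `CCNc1nnc(-c2cc(-c3ccc(F)cc3F)ccc2O)o1`, which has not yet been measured in this assay. The difference between the core of compound 3 and the core of compound 2 is not broken down here. Going by the values given here, the expected step for compound 4 is a number 6.7 percentage points higher from compound 3 to compound 4 (within the scatter), because the only earlier instance of this change was a number 6.7 percentage points higher from compound 2 to compound 1 (within the scatter). Compound 4 is therefore estimated at 40.5%, with a likely range from 29% to 52%.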

Compound 4, a percentage reported as inhibition, in the whole organism at one dose (the size of the read-out at that dose, not a potency): 36.8%
Estimate against measurement, compound 4: 3.7 percentage points above, within the range that was stated.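

In this assay, ethyl in place of 4-methylphenyl on the nitrogen gave a number 3 percentage points higher from compound 3 to compound 4 (within the scatter), and set beside the earlier instance of the change, the two steps do not differ: the same change on two cores in this assay, a number 6.7 percentage points higher (within the scatter) from compound 2 to compound 1 and a number 3 percentage points higher (within the scatter) from compound 3 to compound 4, 3.7 percentage points apart, within the scatter of two such steps

The change therefore carried from one core to the other in this series with no detectable difference in the size of its step. It does not show that the change itself raises the read-out on either core, as each step lies within the scatter, and two cores say nothing about a third.

The compounds shown carry only ethyl and 4-methylphenyl on that nitrogen. As far as these compounds go, how a longer chain such as butyl, or a chain ending in an amine, would behave there on either core remains open.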